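A few compounds are considered here, and "the series" means these few. Any claim that something is new, unique, unknown or untested is made for them only; others in the source may bear on it.

In a functional assay on MCF7 cells (Homo sapiens) for inhibition (a lower number here means a stronger inhibitor, a higher number a weaker inhibitor), the three measured compounds stand as follows:
compound 1 `CCCCCCCCCCCCCCCCCCOC[C@H](COP(=O)(O)O[C@H]1[C@@H](O)[C@@H](O)[C@H](O)C[C@H]1O)OC` gives 7200 nM;
compound 2 `CCCCCCCCCCCCCCCCCCOC[C@H](COP(=O)(O)O[C@@H]1[C@H](O)[C@H](CO)[C@@H](O)[C@H](O)[C@@H]1O)OC` gives 5000 nM;
compound 3 `CCCCCCCCCCCCCCCCCCOC[C@H](COC(=O)O[C@@H]1[C@H](O)[C@H](CO)[C@@H](O)[C@H](O)[C@@H]1O)OC` gives 1200 nM.

Compound 2 and compound 1 differ by hydrogen in place of hydroxymethyl on a saturated ring carbon, and this step was a 1.4-fold higher number from compound 2 to compound 1 (0.16 log units; within the scatter). How the core of compound 3 differs from that of compound 2 is not broken down here; compound 3 simply gives the lowest number of the three, with compound 2 and compound 1 both beyond the scatter above it.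

Compound 4 `CCCCCCCCCCCCCCCCCCOC[C@H](COC(=O)O[C@H]1[C@@H](O)[C@@H](O)[C@H](O)C[C@H]1O)OC` has not been measured. It differs from compound 3 by hydrogen in place of hydroxymethyl on a saturated ring carbon, the same change already seen between compound 2 and compound 1. The expectation for it rests on compound 2, whose step a 1.4-fold higher number from compound 2 to compound 1 (0.16 log units; within the scatter) lay within the scatter, so no large shift is expected. The step expected is a 1.3-fold higher number from compound 3 to compound 4 (0.12 log units; within the scatter). Compound 4 is therefore estimated at 1600 nM, likely between 700 nM and 3600 nM.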

Compound 4, half-maximal inhibitory concentration: 12000 nM
The estimate for compound 4 lay 7.5-fold (0.88 log units) below the measured number; measured number above the stated range.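

In this assay, hydrogen in place of hydroxymethyl on a saturated ring carbon gave a 10-fold higher number from compound 3 to compound 4 (1.00 log units; beyond the scatter), so on this core the change is far from neutral. Two pairs cannot show what sets the size of the step, or how the change would behave on any further core. What they do show is that the step did not carry over at one size from one core to the other: the same change on two cores in this assay, a 1.4-fold higher number (0.16 log units; within the scatter) from compound 2 to compound 1 and a 10-fold higher number (1.00 log units; beyond the scatter) from compound 3 to compound 4, 6.9-fold (0.84 log units) apart, beyond the scatter of two such steps

The compounds shown leave open whether another group on that ring carbon, such as an amine, a carboxylic acid or a longer chain, would hold the number of compound 3 or move it as hydrogen does. They also leave open whether the two cores would part in the same way on a change elsewhere.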